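This account rests on a few compounds, and the source may have more. Where it says the series, first, only, none or still open, it means among the compounds named here.

The three measured compounds in a functional assay on MOLT-4 cells (Homo sapiens) for cytotoxicity (on this read-out higher numbers stand for weaker inhibition and lower numbers for stronger inhibition), are:

compound 1, `Cc1cn([C@H]2C[C@H](SSC(Cl)(Cl)Cl)[C@@H](CO)O2)c(=O)[nH]c1=O`, giving 55000 nM
compound 2, `Cc1cn([C@H]2C[C@H](SSc3ccc([N+](=O)[O-])cc3)[C@@H](CO)O2)c(=O)[nH]c1=O`, giving 29000 nM
compound 3, `CCCCCCSS[C@H]1C[C@H](n2cc(C)c(=O)[nH]c2=O)O[C@@H]1CO`, giving 27000 nM

Compound 3 has the lowest of the three numbers in this assay, but its separation from compound 2 is within the scatter, so the two cannot be told apart; from compound 1 the step was a 2.0-fold lower number from compound 1 to compound 3 (0.31 log units; beyond the scatter), a modest one. Compound 4, `Cc1cn([C@H]2C[C@H](SSCCN)[C@@H](CO)O2)c(=O)[nH]c1=O`, is not yet measured. It differs from compound 3 by amino in place of butyl on a saturated chain carbon, two bonds along the chain from a sulfur. For the measured compounds named here, the steps that bear on this change are those that exchange the group carried on the same sulfur: a 2.0-fold lower number from compound 1 to compound 3 (0.31 log units; beyond the scatter), modest, and a 1.1-fold lower number from compound 2 to compound 3 (0.03 log units; within the scatter), within the scatter, together with a 1.9-fold lower number from compound 1 to compound 2 (0.28 log units; within the scatter), also within the scatter. Three quite different groups on that sulfur have thus shifted the number by at most a small amount. The account therefore expects for compound 4 a step in this assay of no more than modest size, if anything toward a higher number, estimated as a 1.5-fold higher number from compound 3 to compound 4 (0.17 log units; within the scatter). For compound 4 the estimate in this assay is 40000 nM, with a range from 15000 nM to 110000 nM.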

Compound 4, half-maximal inhibitory concentration: 163000 nM
Beside the measured number, compound 4's estimate is 4.1-fold (0.61 log units) below it; measured number above the stated range.
By their numbers in this assay, from the lowest: compounds 3, 2 and 1 (each within the scatter of the next, the first and the last beyond it); then compound 4.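

In this assay the group on this sulfur proves not to be indifferent: amino in place of butyl on a saturated chain carbon, two bonds along the chain from a sulfur, gives a 6.0-fold higher number from compound 3 to compound 4 (0.78 log units; beyond the scatter) and is larger than any step among the three earlier groups. The other two exchanges point the same way, with 2-aminoethyl in place of 4-nitrophenyl giving a 5.6-fold higher number from compound 2 to compound 4 (0.75 log units; beyond the scatter) and 2-aminoethyl in place of trichloromethyl giving a 3.0-fold higher number from compound 1 to compound 4 (0.47 log units; beyond the scatter) as the smallest of the three. The near-flat picture therefore holds only for hexyl, 4-nitrophenyl and trichloromethyl, and it does not extend to 2-aminoethyl. Nothing at hand explains this difference.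

The change shortens the chain and brings in the amine at the same time, so the compounds shown cannot say which of the two goes with the higher number. A plain ethyl group or a 2-hydroxyethyl group on the same sulfur would bear on that question, as would a 6-aminohexyl chain, which keeps the amine on a longer chain, or a carboxylic acid at the chain end.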